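A few compounds are considered here, and "the series" means these few. Any claim that something is new, unique, unknown or untested is made for them only; others in the source may bear on it.

Measured so far in an assay (Ovis aries) for binding affinity to melatonin receptor type 1A (Homo sapiens); a higher number here means a weaker inhibitor, a lower number a stronger inhibitor:
Compound 1, `COc1ccc2cccc(C3CNC(=O)C3)c2c1`: 1580 nM
Compound 2, `CC(=O)NCCC1CCc2ccc(NC(C)=O)cc21`: 10000 nM
Compound 3, `COc1ccc2ncn(CCNC(C)=O)c2c1`: 3160 nM

Among these three numbers, compound 1 holds the lowest. Compound 3 sits closest, yet the gap between compound 1 and compound 3 is within the scatter, so no order between the two is claimed. Compound 2 lies furthest, and that gap is beyond the scatter.

Compound 4, `COc1ccc2cccc(CCC(N)=O)c2c1`, differs from compound 1 in one place: 2-carbamoylethyl in place of 5-oxopyrrolidin-3-yl on an aromatic carbon. For the measured compounds named here, no step between measured compounds covers a change of this kind, so the expectation rests on compound 1 alone. For compound 4 a small step toward a higher number in this assay is expected, a 1.6-fold higher number from compound 1 to compound 4 (0.20 log units; within the scatter), with little confidence that it exceeds the scatter. Compound 4 is therefore estimated at 2500 nM, with a range from 600 nM to 10000 nM.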

Compound 4, half-maximal inhibitory concentration: 1000 nM
For compound 4 the middle estimate is 2.5-fold (0.40 log units) above the measured one; the range from low to high includes it.
By their numbers in this assay, from the lowest: compounds 4, 1 and 3 (each within the scatter of the next, the first and the last beyond it); then compound 2.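

In this assay, the step from ring to open chain on this aromatic carbon gives a 1.6-fold lower number from compound 1 to compound 4 (0.20 log units; within the scatter) and so claims no order between the two. The 5-oxopyrrolidin-3-yl ring is therefore not shown to be required at this position, since 2-carbamoylethyl stays within the scatter of it. Nothing measured here bears on the reason for this result.

Open, going by these compounds, is whether a longer chain on this carbon would stay within the scatter of compound 4 in this assay. Also open, on these data alone, is what an amine or a carboxylic acid would give in place of the carbamoyl end of the chain.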